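A few compounds are considered here, and "the series" means these few. Any claim that something is new, unique, unknown or untested is made for them only; others in the source may bear on it.

Working notes on the series. The three measured compounds share one core and differ only in the substituents on the two peripheral rings. Compound 1 `COc1ncc(-c2ccc3c(c2)N(c2ccc(F)cc2)C(=O)CO3)cc1NS(=O)(=O)c1ccc(F)cc1` gives 36400 nM in a functional assay on HepG2 cells (Homo sapiens) for antiproliferative activity, read by MTT assay, with a stated time of 72 h; a lower number here means a stronger inhibitor, a higher number a weaker inhibitor. Compound 2 `O=C1COc2ccc(-c3cnc(Cl)c(NS(=O)(=O)c4ccc(F)cc4)c3)cc2N1c1ccc(Cl)cc1` gives 33900 nM in this assay. Compound 3 `COc1ncc(-c2ccc3c(c2)N(c2ccc(Cl)cc2)C(=O)CO3)cc1NS(=O)(=O)c1ccc(F)cc1` gives 17900 nM in this assay, the lowest of the three numbers; its step from compound 2 is within the scatter, so no order between those two is claimed, while the step of a 2.0-fold lower number from compound 1 to compound 3 (0.31 log units; beyond the scatter) lies beyond the scatter. The step of a 1.9-fold lower number from compound 2 to compound 3 (0.28 log units; within the scatter) concerns the substituent on the pyridine-type ring and stays within the scatter.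

Compound 4 `COc1ncc(-c2ccc3c(c2)NC(=O)CO3)cc1NS(=O)(=O)c1ccc(F)cc1` is not yet measured. Its difference from compound 3 is hydrogen in place of 4-chlorophenyl on an amide-type nitrogen in a ring. Neither measured step bears directly on this change: both keep an aryl group on the amide-type nitrogen in the ring and vary only halogens or a methoxy elsewhere. Going by the values given here, the one step that touches that aryl group, a 2.0-fold lower number from compound 1 to compound 3 (0.31 log units; beyond the scatter), was modest. Removing the group entirely is a larger change without precedent here, so the direction is uncertain; a higher number is expected as the more likely outcome, with a 2.2-fold higher number from compound 3 to compound 4 (0.35 log units; beyond the scatter) for the step. For compound 4 the estimate in this assay is 40000 nM, expected to fall between 12000 nM and 150000 nM.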

Compound 4, half-maximal inhibitory concentration: 6590 nM
The estimate for compound 4 lay 6.1-fold (0.78 log units) above the measured number; the whole stated range lies above it.
By their numbers in this assay, from the lowest: compound 4; then compounds 3, 2 and 1 (each within the scatter of the next, the first and the last beyond it).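

Hydrogen in place of the aryl group on the amide-type nitrogen in the ring lowers the number in this assay with either halogen form: hydrogen in place of 4-chlorophenyl gives a 2.7-fold lower number from compound 3 to compound 4 (0.43 log units; beyond the scatter) and hydrogen in place of 4-fluorophenyl gives a 5.5-fold lower number from compound 1 to compound 4 (0.74 log units; beyond the scatter) in this series. The earlier steps shown here changed only a halogen on that aryl group or the substituent on the other ring, whereas these two steps show that the aryl group itself is not required for the activity read here, and that both aryl-bearing compounds compared at this position carry higher numbers than compound 4. No measurement in hand explains this change.

What the compounds shown leave open is whether a smaller substituent on that nitrogen, such as methyl, or a longer chain ending in an amine or a carboxylic acid, would hold or further lower the number. Also open is whether the free amide hydrogen gives a similar step with chloro in place of methoxy on the other ring, since every compound shown keeps the same 4-fluorophenyl on the sulfonamide.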